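Dropping the Chloro Group from a Potent Kinase Binder

This account rests on a few compounds, and the source may have more. Where it says the series, first, only, none or still open, it means among the compounds named here.

The measured compounds and their values:
- compound 1 `COC(=O)Nc1cc(-c2cc(Cl)c(OC[C@@](C)(N)CC(C)C)cn2)ccn1`: 0.11 nM
- compound 2 `Cc1cc(-c2cc(Cl)c(OC[C@@](C)(N)CC(C)C)cn2)ccn1`: 0.7 nM
- compound 3 `CC(=O)Nc1cc(-c2ccc(OC[C@@](C)(N)CC(C)C)c(F)c2)ccn1`: 0.24 nM

All three share the (2-amino-2,4-dimethylpentyl)oxy side chain attached to an aromatic ring, with a second aromatic ring carrying a small substituent. In an assay on brain (strain C57BL6) for displacement of a labelled ligand from AP2-associated protein kinase 1 (Mus musculus), read by scintillation counting, with a stated time of 1 h (on this read-out lower numbers stand for stronger inhibition and higher numbers for weaker inhibition), compound 1 gives the lowest number of the three; compound 3 sits nearest to it and compound 2 furthest away. For the measured compounds named here, the only single-point step among the measured compounds is a 6.4-fold higher number from compound 1 to compound 2 (0.80 log units; beyond the scatter), which shows that exchanging the (methoxycarbonyl)amino group for a methyl group weakens binding. Compound 3 differs from compound 1 in more than one place, so its value can only be set beside that of compound 1 without any single change being read from it.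

Compound 4 `COC(=O)Nc1cc(-c2ccc(OC[C@@](C)(N)CC(C)C)cn2)ccn1` is compound 1 with one change: hydrogen in place of chloro on an aromatic carbon

Going by the values given here, no measured step touches this position, so the data give no direct guide to the size or direction of the step. Because compound 1 gives 0.11 nM, the expectation for compound 4 is a number close to it, with a slight loss of binding considered more likely than a gain; the estimated step is a 2.7-fold higher number from compound 1 to compound 4 (0.44 log units; beyond the scatter). Compound 4 is therefore expected to give 0.3 nM, within a range from 0.1 nM to 1 nM.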

Compound 4, inhibition constant: 18 nM
The estimate for compound 4 lay 60-fold (1.78 log units) below the measured number, outside the stated range (above it).
By their numbers in this assay, from the lowest: compound 1; then compound 3; then compound 2; then compound 4.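

Removing the chloro group from the carbon ortho to the (2-amino-2,4-dimethylpentyl)oxy group and opposite the ring nitrogen gives a 160-fold higher number from compound 1 to compound 4 (2.21 log units; beyond the scatter) in this assay. This shows that a single chlorine atom at this position has a large effect on the number, so hydrogen is far from an equivalent replacement in this compound pair. The step is also labelled large, whereas the earlier exchange of the (methoxycarbonyl)amino group for methyl, a 6.4-fold higher number from compound 1 to compound 2 (0.80 log units; beyond the scatter), is labelled modest, and no measurement here explains why losing this one atom changes the number so much.

The compounds shown leave open whether a bromo, methyl or nitrile group at this position would keep a number close to that of compound 1 or give one closer to that of compound 4. They also leave open whether removing the chloro group would have a similar effect if the (methoxycarbonyl)amino group were replaced by another group, such as an amine or the methyl group of compound 2.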